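The compounds below may be only part of what the source reports. "The series", "measured", "known", "first", "only" and "open" are said of these compounds alone.

Compound 1 `COc1ccccc1/C=C/C(=O)NO`: 26900 nM
Compound 2 `CN1CCN(C(=O)ONC(=O)/C=C/c2ccccc2OC(=O)c2ccccc2)CC1`: 45200 nM

In a functional assay on NCI-H23 cells (Homo sapiens) for inhibition, read by ELISA, with a stated time of 24 h (on this read-out higher numbers stand for weaker inhibition of growth and lower numbers for stronger inhibition of growth), compound 1 gives 26900 nM and compound 2 gives 45200 nM. Among the compounds with values here, these two numbers lie within the usual scatter of each other, so the measurements do not separate the compounds, and compound 2 stands level with the only other measured compound.

Compound 3 `O=C(/C=C/c1ccccc1OC(=O)c1ccccc1)NOC(=O)c1ccccc1` differs from compound 2 in one place: phenyl in place of 4-methylpiperazin-1-yl on a carbonyl carbon. It carries phenyl in place of 4-methylpiperazin-1-yl on a carbonyl carbon. Within the data shown here, no measured pair of compounds shows what this exchange does in this assay, so there is no direct evidence for a shift in either direction. The expectation therefore rests on compound 2 at 45200 nM, and no change beyond the scatter is predicted. The estimated change is a 1.3-fold lower number from compound 2 to compound 3 (0.11 log units; within the scatter). For compound 3, the estimated value is 35000 nM, with an expected range of 12000 nM to 90000 nM.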

Compound 3, concentration for 50% growth inhibition: 18200 nM
For compound 3 the middle estimate is 1.9-fold (0.28 log units) above the measured one, and the stated range covers the measured number.
By their numbers in this assay, from the lowest: compounds 3, 1 and 2 (each within the scatter of the next, the first and the last beyond it).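

Replacing 4-methylpiperazin-1-yl with phenyl on this carbonyl carbon gives, in this assay, a 2.5-fold lower number from compound 2 to compound 3 (0.40 log units; beyond the scatter), a modest gain in inhibition of growth. Within the data shown here, this is the first sign that the group at this position can change the read-out, which compound 1 and compound 2 could not show, as those two differ in more than one place and their values lie within the scatter of each other. Nothing at hand gives a reason for this shift.

With only one exchange shown at this position, it remains open whether the gain goes with the presence of phenyl or with the loss of 4-methylpiperazin-1-yl. A cyclohexyl ring, a methyl group or a dimethylamino group on the same carbonyl carbon would help tell these two readings apart.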